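Compound 3 to compound 4: replacing the 4-methylpiperazin-1-yl group

The source may report more compounds than this note shows. Statements on the series, on what has been measured and on what is new or still open speak of the compounds shown alone.

Measured in a functional assay on MDA-MB-231 cells (Homo sapiens) for cytotoxicity, read by MTT assay, with a stated time of 72 h; a higher number here means a weaker inhibitor, a lower number a stronger inhibitor:
- compound 1 `CN(C)CCCCCn1c2c(c3ccccc31)C(=O)c1c[n+]([O-])c3ccccc3c1C2=O` gives 240 nM
- compound 2 `CN1CCN(CCCCn2c3c(c4ccccc42)C(=O)c2c[n+]([O-])c4ccccc4c2C3=O)CC1` gives 110 nM
- compound 3 `CN1CCN(CCCn2c3c(c4ccccc42)C(=O)c2c[n+]([O-])c4ccccc4c2C3=O)CC1` gives 390 nM

Compound 3 lies within the scatter of compound 1, with a 1.6-fold higher number from compound 1 to compound 3 (0.21 log units; within the scatter), and is weaker than compound 2 only, with a 3.5-fold higher number from compound 2 to compound 3 (0.55 log units; beyond the scatter). Compound 4 `O=C1c2c[n+]([O-])c3ccccc3c2C(=O)c2c1c1ccccc1n2CCCN1CCC(O)CC1` differs from compound 3 at one place: 4-hydroxypiperidin-1-yl in place of 4-methylpiperazin-1-yl on a saturated chain carbon, three bonds along the chain from an aromatic nitrogen. In words, this is 4-hydroxypiperidin-1-yl in place of 4-methylpiperazin-1-yl on a saturated chain carbon, three bonds along the chain from an aromatic nitrogen.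

Within the data shown here, no measured step makes this exchange alone. The closest evidence is the two steps that change the terminal group together with the chain, namely a 2.2-fold lower number from compound 1 to compound 2 (0.34 log units; beyond the scatter) and a 1.6-fold higher number from compound 1 to compound 3 (0.21 log units; within the scatter). These two point in opposite directions and are modest at most, so no direction can be favoured. The expected change is a 1.1-fold lower number from compound 3 to compound 4 (0.05 log units; within the scatter) in this assay, which would be no shift beyond the scatter. For compound 4 the estimate is 350 nM, with an expected range from 130 nM to 950 nM in this assay.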

Compound 4, half-maximal inhibitory concentration: 280 nM
Estimate against measurement, compound 4: 1.3-fold (0.10 log units) above; the range from low to high includes it.
By their numbers in this assay, from the lowest: compound 2; then compounds 1, 4 and 3 (each within the scatter of the next).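

In this assay, the exchange of 4-methylpiperazin-1-yl for 4-hydroxypiperidin-1-yl now stands alone on the same propyl chain, and it gives a 1.4-fold lower number from compound 3 to compound 4 (0.14 log units; within the scatter), so the two terminal rings are not separated at this position. Compound 4 is also not separated from the dimethylamino compound, with a 1.2-fold higher number from compound 1 to compound 4 (0.07 log units; within the scatter), while compound 2 keeps the lowest number, with a 2.5-fold higher number from compound 2 to compound 4 (0.41 log units; beyond the scatter). No measurement at hand explains these results.

From the compounds shown here alone, what the hydroxyl contributes apart from the ring nitrogen stays open, and a plain piperidin-1-yl or a morpholin-4-yl group on the same chain would address it. Also open, going by these compounds, is whether 4-hydroxypiperidin-1-yl on the longer chain of compound 2 would follow the piperazine there.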